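Bromo in Place of Methyl on the Aryl Ring

The source may hold more compounds than are shown below. What is called first, only, known or untested is meant among the compounds shown, and "the series" means these compounds.

Compound 1, `Cc1ccc2cnc(-c3cccc(CN)c3)nc2n1`: > 30000 nM
Compound 2, `Cc1cccc(-c2ncc3ccc(C)nc3n2)c1`: 53 nM

In a functional assay on CHO cells for antagonist activity at metabotropic glutamate receptor 5 (Rattus norvegicus), read by FLIPR and calcium flux (a lower number here means a stronger inhibitor, a higher number a weaker inhibitor), compound 2 gives 53 nM. Compound 1 reaches only a limit, > 30000 nM, in this assay. Of the two results shown, the value of compound 2 is the only actual number; the other is a limit (the limit of > 30000 nM in this assay, at which 1 of the 2 values shown sits). Within the data shown here, the single measured step, an at least 560-fold lower number from compound 1 to compound 2 (2.75 log units; beyond the scatter), concerns a change on a saturated chain carbon rather than on the aromatic ring itself, so it offers no direct guide to the next exchange.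

Compound 3, `Cc1ccc2cnc(-c3cccc(Br)c3)nc2n1`, differs from compound 2 by bromo in place of methyl on an aromatic carbon. Among the measured compounds shown here, since an at least 560-fold lower number from compound 1 to compound 2 (2.75 log units; beyond the scatter) records a different kind of change, no measured step bears on this swap, and a step no larger than the usual scatter is expected in this assay, in either direction. The expected change is a 1.1-fold higher number from compound 2 to compound 3 (0.05 log units; within the scatter). Compound 3 is therefore estimated at 60 nM, with a range from 20 nM to 200 nM.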

Compound 3, half-maximal inhibitory concentration: 38 nM
The estimate for compound 3 lay 1.6-fold (0.20 log units) above the measured number, and the stated range covers the measured number.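

Putting bromo in place of methyl on this aromatic carbon gives a 1.4-fold lower number from compound 2 to compound 3 (0.14 log units; within the scatter), so the two groups cannot be told apart in this assay. Putting bromo in place of aminomethyl on the same carbon gives an at least 780-fold lower number from compound 1 to compound 3 (2.89 log units; beyond the scatter), so the very weak result now sets aminomethyl apart from two other groups, methyl and bromo, rather than from methyl alone. The value of compound 1 is a limit, not a number, so this step has no exact size: the limit of > 30000 nM in this assay, at which 1 of the 3 values shown sits.

From the compounds shown here alone, only methyl, bromo and aminomethyl appear at this carbon, so the outcome with a methoxy group, a nitrile or a carboxylic acid remains open. Going by these compounds, it is also open whether the amine itself or the longer chain of aminomethyl goes with the weak result, and a simple ethyl group or a longer chain ending in an alcohol would bear on that.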